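Methoxy for chloro on the benzyl group of compound 2

The source may hold more compounds than are shown below. What is called first, only, known or untested is meant among the compounds shown, and "the series" means these compounds.

Measured compounds
Compound 1, `COc1ccc2c(c1)c(/C=N\NC(=O)c1c[nH]c3ccccc13)cn2Cc1ccc(Cl)cc1`, 8700 nM
Compound 2, `O=C(N/N=C\c1cn(Cc2ccc(Cl)cc2)c2cc(F)ccc12)c1c[nH]c2ccccc12`, 6000 nM
Compound 3, `Cn1cc(C(=O)N/N=C\c2cn(Cc3ccc(Cl)cc3)c3cc(F)ccc23)c2ccccc21`, 90600 nM

In a functional assay on MCF7 cells (Homo sapiens) for cytotoxicity (a lower number here means a stronger inhibitor, a higher number a weaker inhibitor), compound 2 gives the lowest of the three numbers; its nearest neighbour is compound 1, whose value sits within the scatter of it, so the two cannot be ordered. For the measured compounds named here, compound 3 lies far from both: the step of a 15-fold higher number from compound 2 to compound 3 (1.18 log units; beyond the scatter) is the only single-place change in the set, and it concerns the hydrogen on the aromatic nitrogen of the acyl hydrazide part, not the benzyl group.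

Compound 4, `COc1ccc(Cn2cc(/C=N\NC(=O)c3c[nH]c4ccccc34)c3ccc(F)cc32)cc1`, is not yet measured. It differs from compound 2 in one place: methoxy in place of chloro on an aromatic carbon. Going by the values given here, none of the measured steps touches this position. Compound 1 and compound 2 carry the same 4-chlorobenzyl group and differ elsewhere, so their values say nothing about the benzyl substituent either. The large step from compound 2 to compound 3 does not bear on a change at the benzyl group.

Among the compounds with values here, with no relevant step to lean on, compound 4 is expected to stay close to compound 2 in this assay, with the step of a 1.3-fold higher number from compound 2 to compound 4 (0.12 log units; within the scatter) estimated to fall within the scatter. The value of compound 4 is estimated at 8000 nM, in the range 3000 nM to 25000 nM.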

Compound 4, half-maximal inhibitory concentration: 13100 nM
Estimate against measurement, compound 4: 1.6-fold (0.21 log units) below, within the range that was stated.
By their numbers in this assay, from the lowest: compounds 2, 1 and 4 (each within the scatter of the next, the first and the last beyond it); then compound 3.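

In this assay the benzyl group proves to be a position where a substituent change registers, though not strongly: the replacement of chloro by methoxy gives a 2.2-fold higher number from compound 2 to compound 4 (0.34 log units; beyond the scatter), a modest step but one beyond the scatter. On an aromatic carbon para to a large group, this single change costs far less than the methyl placed on the aromatic nitrogen, which gives a 15-fold higher number from compound 2 to compound 3 (1.18 log units; beyond the scatter), so among the two single-place changes shown from compound 2, the benzyl substituent is the more forgiving site. Nothing at hand accounts for the difference between the 4-chlorobenzyl and 4-methoxybenzyl compounds.

With only chloro and methoxy shown at this place, the series does not separate what the leaving chloro contributes from what the entering methoxy contributes, and it does not show whether an unsubstituted benzyl group, an amine or a carboxylic acid at the same place would fall near these values. It also leaves open whether the same change would give a step of similar size on the core of compound 1.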